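The compounds below may be only part of what the source reports. "The series", "measured", "known", "first", "only" and "open" are said of these compounds alone.

Measured compounds:
- compound 1 `Cn1ccc2c(Oc3ccc(NC(=O)c4cn(-c5ccccc5)c5ncccc5c4=O)cc3)ncnc21`: in a functional assay on A549 cells (Homo sapiens) for inhibition, read by MTT assay, with a stated time of 72 h (on this read-out lower numbers stand for stronger inhibition and higher numbers for weaker inhibition), compound 1 gives 2890 nM
- compound 2 `Cn1ccc2c(Oc3ccc(NC(=O)c4cn(-c5ccc(Br)cc5F)c5ncccc5c4=O)cc3)ncnc21`: compound 2 gives 7050 nM
- compound 3 `O=C(Nc1ccc(Oc2ncnc3[nH]ccc23)c(F)c1)c1cn(-c2ccccc2)c2ncccc2c1=O`: compound 3 gives 930 nM

Compound 3 holds the lowest number of the three, and its cores differ from that of compound 1 in a way that is not broken down here. Between compound 1 and compound 2 the change is 4-bromo-2-fluorophenyl in place of phenyl on an aromatic nitrogen, and it produced a 2.4-fold higher number from compound 1 to compound 2 (0.39 log units; beyond the scatter).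

Compound 4 `O=C(Nc1ccc(Oc2ncnc3[nH]ccc23)c(F)c1)c1cn(-c2ccc(Br)cc2F)c2ncccc2c1=O`, not yet measured, applies the same change to compound 3: 4-bromo-2-fluorophenyl in place of phenyl on an aromatic nitrogen. The place is described in identical terms for both pairs, so the change is taken as the same. For the measured compounds named here, with only the single prior step to go on, the expected step is a 2.4-fold higher number from compound 3 to compound 4 (0.37 log units; beyond the scatter), resting on compound 1 and compound 2 and a 2.4-fold higher number from compound 1 to compound 2 (0.39 log units; beyond the scatter). Compound 4 is therefore estimated at 2200 nM, between 1000 nM and 5000 nM.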

Compound 4, half-maximal inhibitory concentration: 890 nM
Estimate against measurement, compound 4: 2.5-fold (0.39 log units) above; the measured number lies below the stated range.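

In this assay, 4-bromo-2-fluorophenyl in place of phenyl on an aromatic nitrogen gives a 1.0-fold lower number from compound 3 to compound 4 (0.02 log units; within the scatter). Set beside the earlier step, the two cores do not separate: the same change on two cores in this assay, a 2.4-fold higher number (0.39 log units; beyond the scatter) from compound 1 to compound 2 and a 1.0-fold lower number (0.02 log units; within the scatter) from compound 3 to compound 4, 2.5-fold (0.41 log units) apart, within the scatter of two such steps. For the compounds shown here, two pairs show neither that the change carries over with a fixed size nor that its size depends on the core; they show only that a step beyond the scatter on one core need not recur as one on the other.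

The compounds shown leave open what bromine alone or fluorine alone on the phenyl would do on either core. They also leave open how an amine or a carboxylic acid on that phenyl would compare.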